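This account rests on a few compounds, and the source may have more. Where it says the series, first, only, none or still open, it means among the compounds named here.

Measured compounds:
Compound 1, `Cc1cc(O)c(C(=O)/C=C/c2ccc(F)cc2)c(-c2ccccc2)c1C(=O)/C=C/c1ccc(F)cc1`: 20000 nM
Compound 2, `Cc1cc(O)c(C(=O)/C=C/c2ccc(OCc3ccccc3)cc2)c(-c2ccccc2)c1C(=O)/C=C/c1ccc(OCc2ccccc2)cc1`: 10000 nM
Compound 3, `Cc1cc(O)c(C(=O)/C=C/c2cccc3ccccc23)c(-c2ccccc2)c1C(=O)/C=C/c1cccc2ccccc12`: 30000 nM

These three share one core and differ only at the ends of the two side arms. In a functional assay on MCF7 cells (Homo sapiens) for cytotoxicity, read by MTT assay, with a stated time of 24 h (a higher number here means a weaker inhibitor, a lower number a stronger inhibitor), compound 2 gives the lowest of the three numbers. Compound 1 sits close to it, with a gap within the scatter, while compound 3 gives a number beyond the scatter above it.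

Compound 4, `Cc1cc(O)c(C(=O)/C=C/c2ccc(OCc3ccccc3)cc2)c(-c2ccc(Br)cc2)c1C(=O)/C=C/c1ccc(OCc2ccccc2)cc1`, has not been measured. It differs from compound 2 by bromo in place of hydrogen on an aromatic carbon. For the measured compounds named here, no measured pair here shows what such a change does, so the size of the step is unknown. The expected step from compound 2 to compound 4 is a 1.3-fold lower number from compound 2 to compound 4 (0.10 log units; within the scatter), not beyond the scatter in either direction. Compound 4 is therefore estimated at 8000 nM, in the range 3000 nM to 25000 nM.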

Compound 4, half-maximal inhibitory concentration: 20000 nM
Estimate against measurement, compound 4: 2.5-fold (0.40 log units) below, and the stated range covers the measured number.
By their numbers in this assay, from the lowest: compounds 2, 1, 4 and 3 (each within the scatter of the next, the first and the last beyond it).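

The change from phenyl to 4-bromophenyl is the first one shown away from the ends of the two side arms. In this assay the step is a 2.0-fold higher number from compound 2 to compound 4 (0.30 log units; within the scatter), so adding bromo at this place gives no difference that can be told apart from repeat measurements. No evidence is available that bears on this result.

Going by these compounds, it remains open whether an amine or a carboxylic acid at this same place would move the number beyond the scatter. Also open, on these data alone, is whether bromo would behave the same way with the side arms of compound 1 or compound 3.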